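Dichloroacetamides on a biaryl core: thiophene to phenyl

This account rests on a few compounds, and the source may have more. Where it says the series, first, only, none or still open, it means among the compounds named here.

Two compounds of the series have numbers in a functional assay on NCI-H460 cells (Homo sapiens) for cytotoxicity, read by MTT assay, with a stated time of 68 h; on this read-out lower numbers stand for stronger inhibition and higher numbers for weaker inhibition. Compound 1, `O=C(Nc1cccc(-c2cccs2)c1)C(Cl)Cl`, gives in this assay only a limit, > 50000 nM, not a number. Compound 1 thus stands at the weak end of what is shown, resting on (the limit of > 50000 nM in this assay, at which 1 of the 2 values shown sits). Compound 2, `O=C(Nc1cc(-c2ccc(OC3CCCCO3)cc2)cc(-c2ccc(OC3CCCCO3)cc2)c1)C(Cl)Cl`, carries two aryl groups on the shared core and gives in this assay 2420 nM. Going by the values given here, no step between measured compounds that differ in one place is available, so the two values are read only side by side.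

Compound 3, `O=C(Nc1cccc(-c2ccccc2)c1)C(Cl)Cl`, is not yet measured. It differs from compound 1 by phenyl in place of thiophen-2-yl on an aromatic carbon. The change keeps one aromatic ring in the same place on the core and exchanges only the ring type. Among the compounds with values here, no measured step supports a direction for this exchange, so no move beyond the usual scatter is expected, and the value is expected to remain at or near the limit.

For compound 3 the expected value in this assay is 60000 nM, within 20000 nM to 200000 nM. The step expected is a step that the limit leaves unreadable from compound 1 to compound 3.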

Compound 3, half-maximal inhibitory concentration: 20200 nM
For compound 3 the middle estimate is 3.0-fold (0.47 log units) above the measured one; the measured number falls inside the stated range.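

This gives the series its first step between compounds that differ in one place: in this assay, phenyl in place of thiophen-2-yl on an aromatic carbon gives an at least 2.4-fold lower number from compound 1 to compound 3 (0.39 log units; beyond the scatter). At this place on the shared core, meta to a group of 6 heavy atoms, the exchange of a five-membered aromatic ring with 1 hetero atom for a six-membered aromatic ring of carbon only is thus enough to give a measured number, with compound 3 at 20200 nM. The step can be stated only as a minimum, and its full size stays unread, because compound 1 rests on a limit and not on a number: the limit of > 50000 nM in this assay, at which 1 of the 3 values shown sits.

The compounds shown leave open whether a methoxy group, an amine or a carboxylic acid on the phenyl ring would move the number in this assay further in either direction. Compound 2 differs from compound 3 in more than one place, so what its two aryl groups contribute cannot be read from these values.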